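Swapping the amide end of a weak cell-growth inhibitor

The source may report more compounds than this note shows. Statements on the series, on what has been measured and on what is new or still open speak of the compounds shown alone.

compound 1 `Cn1c(/C=C2\SC(=O)N(CC(=O)Nc3cc(C(C)(C)C)on3)C2=O)nc2ccccc21`: 15300 nM
compound 2 `CCn1c(/C=C2\SC(=O)N(CC(=O)N3CCCCC3)C2=O)nc2ccccc21`: > 50000 nM

In a functional assay on A549 cells (Homo sapiens) for inhibition, read by MTT assay, with a stated time of 48 h (a lower number here means a stronger inhibitor, a higher number a weaker inhibitor), compound 1 gives 15300 nM, the only finished number among the two results shown. Compound 2 reaches only a limit of the assay, > 50000 nM. Among the measured compounds shown here, compound 2 differs from compound 1 in more than one place, so no single step can be read between them; the two values show only that neither compound is a strong inhibitor. Compound 3, `Cn1c(/C=C2\SC(=O)N(CC(=O)N3CCOCC3)C2=O)nc2ccccc21`, has not been measured yet. It keeps the core of compound 1 and changes only the amide end: morpholin-4-yl in place of (5-(tert-butyl)-1,2-oxazol-3-yl)amino on a carbonyl carbon. Both results so far are weak, and the limit of > 50000 nM in this assay, at which 1 of the 2 values shown sits, shows that this assay can return no number at all. The step of a 2.6-fold higher number from compound 1 to compound 3 (0.42 log units; beyond the scatter) is expected to be a loss of potency, toward that limit. Compound 3 is therefore estimated at 40000 nM, with a range from 12000 nM to 120000 nM.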

Compound 3, half-maximal inhibitory concentration: 38500 nM
Beside the measured number, compound 3's estimate is 1.0-fold (0.02 log units) above it, within the range that was stated.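

Among the compounds shown here, the change at the amide end gives the first step that can be read at this position: in this assay, moving to morpholin-4-yl gives a 2.5-fold higher number from compound 1 to compound 3 (0.40 log units; beyond the scatter), a modest loss of potency. The swap removes a hydrogen-bond donor and an aromatic ring and also leaves a smaller group on the carbonyl carbon, so this single step cannot show which of these differences matters. The weaker compound 3 still gives a finished number rather than reaching the assay's ceiling: the limit of > 50000 nM in this assay, at which 1 of the 3 values shown sits.

For the compounds shown here, compound 2 differs from the other two compounds in more than one place, so no step to it can be read. The compounds shown leave open how a phenylamino group on the same carbonyl carbon would compare, since it would keep an amide hydrogen and an aromatic ring without the tert-butyl group.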